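The source may hold more compounds than are shown below. What is called first, only, known or untested is meant among the compounds shown, and "the series" means these compounds.

Measured compounds:
compound 1 `Cn1ncc(Cl)c1-c1cc(C(=O)N[C@H]2CNCC[C@@H]2c2ccc(C(F)(F)F)cc2)oc1Cl` gives 900 nM;
compound 2 `O=C(N[C@@H]1CNCC[C@H]1c1ccc(Cl)cc1)c1ccc(-c2ncnc3c2CCC3O)s1` gives 24100 nM;
compound 3 `Cn1ncc(Cl)c1-c1cc(C(=O)N[C@@H]2CN[C@H](CC(=O)O)C[C@H]2c2ccc(Cl)c(Cl)c2)oc1Cl` gives 5120 nM.

These three numbers come from a functional assay on OVCAR-8 cells (Homo sapiens) for antiproliferative activity; on this read-out higher numbers stand for weaker inhibition and lower numbers for stronger inhibition. Among them compound 3 holds the second highest number: compound 2 sits higher by a margin beyond the scatter, and compound 1 sits lower, again beyond the scatter. Compound 4 `COCC[C@@H]1C[C@@H](c2ccc(Cl)c(Cl)c2)[C@H](NC(=O)c2cc(-c3c(Cl)cnn3C)c(Cl)o2)CN1` has not yet been measured. It differs from compound 3 in a single place: methoxymethyl in place of carboxy on a saturated chain carbon bound to a saturated ring carbon. For the measured compounds named here, no measured pair shows this exchange, so the direction can only be guessed. The expected step from compound 3 to compound 4 is a 3.4-fold lower number from compound 3 to compound 4 (0.53 log units; beyond the scatter), toward a lower number, since compound 1, the one without a carboxy, gives 900 nM. For compound 4 the estimate is 1500 nM, within a range of 400 nM to 6000 nM.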

Compound 4, half-maximal inhibitory concentration: 1060 nM
For compound 4 the middle estimate is 1.4-fold (0.15 log units) above the measured one; the measured number falls inside the stated range.
By their numbers in this assay, from the lowest: compounds 1 and 4 (each within the scatter of the next); then compound 3; then compound 2.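

In this assay, for the compounds shown here, methoxymethyl in place of carboxy on a saturated chain carbon bound to a saturated ring carbon gives a 4.8-fold lower number from compound 3 to compound 4 (0.68 log units; beyond the scatter), the first direct reading of a change at this position. Both groups have 3 heavy atoms, yet the number moves beyond the scatter, so this position is sensitive to which group sits there, not only to how many heavy atoms it has. Nothing measured here gives a reason for the step.

On these data alone, it remains open how an amine or a longer ether chain at this position would compare. A single exchange also cannot separate the effect of losing the carboxy from that of gaining the methoxymethyl.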